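Lengthening the hydroxy arm of compound 3

A few compounds are considered here, and "the series" means these few. Any claim that something is new, unique, unknown or untested is made for them only; others in the source may bear on it.

The measured compounds in a functional assay on DLD-1 cells (Homo sapiens) for antiproliferative activity, read by CellTiter-Glo, with a stated time of 72 h; a lower number here means a stronger inhibitor, a higher number a weaker inhibitor:
Compound 1 `Cc1cc(C)c(S(=O)(=O)N2CCC(C3OCC(C)CO3)CC2)c(C)c1` gives only a limit, > 5000 nM.
Compound 2 `CC1CCN(C2CCN(S(=O)(=O)c3cccnc3Cl)CC2)CC1` likewise gives only a limit, > 5000 nM.
Compound 3 `Cc1cc(C)c(S(=O)(=O)N2CCC(N3CCC(O)CC3)CC2)c(C)c1` gives 106 nM.

Among the measured compounds shown here, compound 3 therefore holds the only actual number in this set; the other two values are limits, as the limit of > 5000 nM in this assay, at which 2 of the 3 values shown sit, shows. For the measured compounds named here, the single measured step, an at least 47-fold lower number from compound 1 to compound 3 (1.67 log units; beyond the scatter), replaces one whole ring group with another and offers no guide to a small change made on the ring that carries the hydroxy group.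

Compound 4 `Cc1cc(C)c(S(=O)(=O)N2CCC(N3CCC(CCO)CC3)CC2)c(C)c1` differs from compound 3 by 2-hydroxyethyl in place of hydroxy on a saturated ring carbon. Going by the values given here, no measured step touches a change of this kind, so nothing here points to a shift beyond the scatter in this assay in either direction. Compound 4 is thus expected to give an estimated 150 nM, with a range of 50 nM to 500 nM. This means an expected step of a 1.4-fold higher number from compound 3 to compound 4 (0.15 log units; within the scatter), within the scatter.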

Compound 4, half-maximal inhibitory concentration: 19 nM
The estimate for compound 4 lay 7.9-fold (0.90 log units) above the measured number; the whole stated range lies above it.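

In this assay, the ring carbon three ring bonds from the ring nitrogen responds to a small change: 2-hydroxyethyl in place of hydroxy gives a 5.6-fold lower number from compound 3 to compound 4 (0.75 log units; beyond the scatter) while the rest of the molecule stays the same. Among the compounds shown here, the earlier compounds could not show this, as their only measured step swapped one whole ring group for another. That wider comparison now reads an at least 260-fold lower number from compound 1 to compound 4 (2.42 log units; beyond the scatter) with the new arm in place. Compound 1 gives only a limit, so this step is a bound and not an exact size: the limit of > 5000 nM in this assay, at which 2 of the 4 values shown sit.

As far as these compounds go, whether a longer chain such as 3-hydroxypropyl, or an arm ending in an amine or a carboxylic acid, would lower the number further remains open. The compounds shown also cannot tell whether the gain needs the oxygen of the arm, since a plain ethyl group appears in none of them.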